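A few compounds are considered here, and "the series" means these few. Any claim that something is new, unique, unknown or untested is made for them only; others in the source may bear on it.

In a functional assay on LNCaP cells (Homo sapiens) for antiproliferative activity, read by propidium iodide staining, with a stated time of 96 h (a lower number here means a stronger inhibitor, a higher number a weaker inhibitor), the measured compounds give these values:
- Compound 1 `CC(O)(CS(=O)(=O)c1ccc(S(F)(F)(F)(F)F)cc1)C(=O)Nc1cccc(S(F)(F)(F)(F)F)c1` gives 11700 nM
- Compound 2 `CC(O)(CS(=O)(=O)c1ccccc1C(F)(F)F)C(=O)Nc1cccc(S(F)(F)(F)(F)F)c1` gives 24900 nM
- Compound 3 `CC(O)(CS(=O)(=O)c1ccc(OC(F)(F)F)cc1)C(=O)Nc1cccc(S(F)(F)(F)(F)F)c1` gives 10700 nM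

a 1.1-fold lower number from compound 1 to compound 3 (0.04 log units; within the scatter) and a 2.3-fold lower number from compound 2 to compound 3 (0.37 log units; beyond the scatter) are the two steps that place compound 3, and only the second lies beyond the scatter.

Compound 4 `CC(O)(CS(=O)(=O)c1ccccc1OC(F)(F)F)C(=O)Nc1cccc(S(F)(F)(F)(F)F)c1` has 2-(trifluoromethoxy)phenyl in place of 4-(trifluoromethoxy)phenyl on a sulfonyl sulfur, the same atoms joined differently. Going by the values given here, no measured pair shows this change alone. The closest guide is compound 2 (24900 nM), which carries 2-(trifluoromethyl)phenyl, although its modest step to compound 3 also changed the group itself. The swap of group between compound 1 and compound 3 (10700 nM) stayed within the scatter. A modest rise in this assay is therefore expected, of about the size seen with compound 2. The expected change is a 1.9-fold higher number from compound 3 to compound 4 (0.27 log units; within the scatter) in this estimate. For compound 4 the estimated value is 20000 nM with an expected range from 10000 nM to 40000 nM in repeat measurements.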

Compound 4, half-maximal inhibitory concentration: 9000 nM
Compound 4: middle estimate off by 2.2-fold (0.35 log units), on the high side; the whole stated range lies above it.
By their numbers in this assay, from the lowest: compounds 4, 3 and 1 (each within the scatter of the next); then compound 2.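

In this assay, 2-(trifluoromethoxy)phenyl in place of 4-(trifluoromethoxy)phenyl on a sulfonyl sulfur gives a 1.2-fold lower number from compound 3 to compound 4 (0.08 log units; within the scatter), so this pair cannot be told apart, and moving the trifluoromethoxy group around the ring has no readable effect here. The second step, with trifluoromethoxy in place of trifluoromethyl on an aromatic carbon, gives a 2.8-fold lower number from compound 2 to compound 4 (0.44 log units; beyond the scatter), so among these compounds the high number of compound 2 goes with 2-(trifluoromethyl)phenyl and not with every 2-substituted ring. Nothing measured here explains why these two groups differ.

The compounds shown leave open how a 4-(trifluoromethyl)phenyl group would compare with the 2-(trifluoromethyl)phenyl group of compound 2. They also leave open whether a smaller group on the ring, such as a methoxy, a nitrile or an amine, would follow compound 4 or compound 2.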